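The compounds below may be only part of what the source reports. "The series", "measured", "known", "first", "only" and "open" are said of these compounds alone.

Working notes on the series.

Compound 1 `C/C(=C\CC/C(C)=C/CC[C@@H]1[C@@]2(C)CCC(=O)C(C)(C)[C@H]2CC[C@@]1(C)O)CC/C=C(\C)C(=O)OCc1cn(-c2ccccc2C)nn1`, compound 2 `C/C(=C\CC/C(C)=C/CC[C@@H]1[C@@]2(C)CCC(=O)C(C)(C)[C@H]2CC[C@@]1(C)O)CC/C=C(\C)C(=O)OCc1cn(-c2ccccc2Cl)nn1` and compound 3 `C/C(=C\CC/C(C)=C/CC[C@@H]1[C@@]2(C)CCC(=O)C(C)(C)[C@H]2CC[C@@]1(C)O)CC/C=C(\C)C(=O)OCc1cn(-c2ccc(Cl)cc2)nn1` share one core and differ only in the aryl group carried on the triazole nitrogen. In an ADME assay on L132 cells (Homo sapiens) for cytotoxicity, read by MTT assay, with a stated time of 48 h (a lower number here means a stronger inhibitor, a higher number a weaker inhibitor), compound 1 gives a value that is a limit of the assay, > 150000 nM. In this assay compound 2 likewise returns only a limit, > 150000 nM. In this assay compound 3 also sits at a limit, > 150000 nM. The step from compound 2 to compound 1 is methyl in place of chloro on an aromatic carbon and in this assay reads a step that the two limits leave unreadable from compound 2 to compound 1. The rearrangement of the aryl group, (4-chlorophenyl in place of 2-chlorophenyl on an aromatic nitrogen), gives a step that the two limits leave unreadable from compound 2 to compound 3, and the further step that the two limits leave unreadable from compound 1 to compound 3 is equally unreadable, because of the limit of > 150000 nM in this assay, at which 3 of the 3 values shown sit.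

Compound 4 `C/C(=C\CC/C(C)=C/CC[C@@H]1[C@@]2(C)CCC(=O)C(C)(C)[C@H]2CC[C@@]1(C)O)CC/C=C(\C)C(=O)OCc1cn(-c2ccc(C)cc2)nn1` is not yet measured. It differs from compound 3 by methyl in place of chloro on an aromatic carbon. Going by the values given here, this is the same kind of change as the one from compound 2 to compound 1, but the surroundings differ: in the earlier pair the exchanged group sits ortho to a large group, here it sits para to a large group. Since compound 3 gives only a limit, > 150000 nM, and every other member of the series also sits at that limit, the step from compound 3 to compound 4 in this assay is expected to be a step that the limit leaves unreadable from compound 3 to compound 4, most probably again unreadable. Compound 4 is accordingly estimated at 200000 nM in this assay, within 100000 nM to 600000 nM, with a high chance that only a limit is reported.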

Compound 4, half-maximal inhibitory concentration: > 150000 nM
Compound 4 gave a limit, no number; the forecaster's own chance of this, stated with the estimate: 85%; the middle value is on the limit's open side.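

In this assay compound 4 gives > 150000 nM, which is a limit of the assay. Going by these compounds alone, no step from compound 1, compound 2 or compound 3 to compound 4 can be read, because all the results are limits: the limit of > 150000 nM in this assay, at which 4 of the 4 values shown sit. The compounds shown leave open what concentration of any of them reaches half-maximal inhibition, and whether the aryl group on the triazole nitrogen changes it.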